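Fluoro for Methyl at the Weak End of the Series

A few compounds are considered here, and "the series" means these few. Any claim that something is new, unique, unknown or untested is made for them only; others in the source may bear on it.

Compound 1, `CCOC(=O)c1c(-c2c(Cl)c3ccccc3oc2=O)nn(-c2ccccc2)c1C(=O)OCC`: 34000 nM in a functional assay on A549 cells (Homo sapiens) for cytotoxicity, read by MTT assay, with a stated time of 48 h; a higher number here means a weaker inhibitor, a lower number a stronger inhibitor
Compound 2, `COC(=O)c1c(-c2cc3ccccc3oc2=O)nn(-c2cccc(C)c2)c1C(=O)OC`: 51000 nM in this assay

Of the compounds shown here, two have been measured so far, and both sit at high concentrations in this assay, which marks them as weak inhibitors of the cancer cell line. Compound 2 gives the higher of the two numbers, but the gap to compound 1 falls within the usual scatter of repeated measurements, so the two cannot be told apart on the data in hand.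

Compound 3, `COC(=O)c1c(-c2cc3ccccc3oc2=O)nn(-c2cccc(F)c2)c1C(=O)OC`, is the next step from compound 2. The change is fluoro in place of methyl on an aromatic carbon. Within the data shown here, no measured pair shows this exact swap, so there is no step to lean on. With both measured compounds clustered at the weak end, the expectation is that compound 3 stays in the same region: a step of a 1.1-fold lower number from compound 2 to compound 3 (0.05 log units; within the scatter) is expected, meaning no movement beyond the scatter in either direction. Compound 3 is therefore estimated at 45000 nM in this assay, with a likely range from 18000 nM to 110000 nM.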

Compound 3, half-maximal inhibitory concentration: 50000 nM
Beside the measured number, compound 3's estimate is 1.1-fold (0.05 log units) below it; measured number inside the range.
By their numbers in this assay, from the lowest: compounds 1, 3 and 2 (each within the scatter of the next).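

In this assay, among these compounds, putting fluoro in place of methyl on this aromatic carbon gives a 1.0-fold lower number from compound 2 to compound 3 (0.01 log units; within the scatter) and provides the first direct comparison, since compound 2 and compound 3 differ in this one place alone. Exchanging the 3-methylphenyl group for the 3-fluorophenyl group therefore produces no change that can be told apart from ordinary assay scatter, and both compounds remain in the high-concentration region that marks weak inhibitors. Nothing measured on hand accounts for this flat result, and a single exchange of two small groups cannot show whether the position matters more broadly.

The compounds shown leave open whether a quite different group at this place on the phenyl ring, such as an amine, a carboxylic acid or a longer alkyl chain, would move the number beyond the scatter. They also leave open how the chloro group and ethyl esters of compound 1 each contribute, as compound 1 differs from compound 2 and compound 3 in several places at once and offers no single-change comparison.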